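The source may hold more compounds than are shown below. What is called first, only, known or untested is meant among the compounds shown, and "the series" means these compounds.

Going by the values given here, in a functional assay on DU-145 cells (Homo sapiens) for cytotoxicity, read by MTT assay (on this read-out higher numbers stand for weaker inhibition and lower numbers for stronger inhibition), compound 1 (`CC(C)=CC[C@@H](OC(=O)C1CCOC1)C1=CC(=O)c2c(O)ccc(O)c2C1=O`) gives 47500 nM while compound 2 (`CC[C@@](C)(O)CC(=O)O[C@H](CC=C(C)C)C1=CC(=O)c2c(O)ccc(O)c2C1=O`) gives 12700 nM as the lower of the only two numbers so far. Compound 2 is therefore the stronger inhibitor of this pair. Compound 3 (`CCC(CO[C@H](CC=C(C)C)C1=CC(=O)c2c(O)ccc(O)c2C1=O)OC`) differs from compound 2 by 2-methoxybutyl in place of (2-hydroxy-2-methylbutyl)carbonyl on an oxygen on a saturated carbon and this places 2-methoxybutyl in place of (2-hydroxy-2-methylbutyl)carbonyl on an oxygen on a saturated carbon. Among the compounds with values here, the only measured step is a 3.7-fold lower number from compound 1 to compound 2 (0.57 log units; beyond the scatter) and it is modest. That step exchanges one group on the carbonyl for another and keeps the carbonyl itself, so it is only a loose guide here. Within the data shown here, no measured compound lacks the carbonyl, and the data favour no direction. The expected step is thus a 1.2-fold higher number from compound 2 to compound 3 (0.07 log units; within the scatter) and no change beyond the scatter is expected. For compound 3 the estimated value is 15000 nM with 5000 nM to 45000 nM as the expected range.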

Compound 3, half-maximal inhibitory concentration: 45700 nM
Beside the measured number, compound 3's estimate is 3.0-fold (0.48 log units) below it; measured number above the stated range.
By their numbers in this assay, from the lowest: compound 2; then compounds 3 and 1 (each within the scatter of the next).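

Compound 3 is the first compound shown without a carbonyl on this oxygen, and in this assay replacing (2-hydroxy-2-methylbutyl)carbonyl with 2-methoxybutyl gives a 3.6-fold higher number from compound 2 to compound 3 (0.56 log units; beyond the scatter) as the result. So the group on this oxygen can move the number beyond the scatter even when the shared core stays the same. Losing the carbonyl cannot be the whole story, however: a 1.0-fold lower number from compound 1 to compound 3 (0.02 log units; within the scatter) shows that compound 3, without a carbonyl, and compound 1, with one, read alike, so compound 1 goes against any simple rule that a carbonyl here gives the lower number.

The change in compound 2 removes the carbonyl and the hydroxy group together, and no evidence on hand separates them or explains the step. Going by these compounds, it also stays open how an amine, a carboxylic acid or a longer chain on this oxygen would read.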